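Sulfonyl aryl change on the naphthyloxyacetyl sulfonamide series

This account rests on a few compounds, and the source may have more. Where it says the series, first, only, none or still open, it means among the compounds named here.

Measured so far:
Compound 1 `COc1ccc2ccc(OCC(=O)NS(=O)(=O)c3ccc4ccccc4c3)cc2c1`: 5000 nM in an assay on isolated protein for activation of Rap guanine nucleotide exchange factor 3 (Homo sapiens), read by fluorescence, in the presence of a further agent that is not named here; a higher number here means that more compound is needed for the effect, a lower number that less compound is needed
Compound 2 `COc1ccc(S(=O)(=O)NC(=O)COc2ccc3ccccc3c2)c(OC)c1`: 5000 nM in this assay

Compound 1 stands level with compound 2 at the digits shown; the two values lie within the usual scatter of each other, so no order between them is claimed. Compound 3 `COc1ccc2ccc(OCC(=O)NS(=O)(=O)c3ccc(N)cc3OC)cc2c1` is unmeasured. It differs from compound 1 only in a group of 9 heavy atoms (7 carbon, 1 nitrogen, 1 oxygen; one six-membered aromatic ring of carbon only) in place of a group of 10 heavy atoms (10 carbon; 2 six-membered aromatic rings of carbon only), on a sulfonyl sulfur. Among the measured compounds shown here, no step between measured compounds touches the group on the sulfonyl sulfur, so nothing gives the size of such a change. The expectation for the step from compound 1 to compound 3 is therefore one of no change beyond the scatter, no change at the digits printed from compound 1 to compound 3 (within the scatter). On that basis compound 3 is estimated at 5000 nM, with a range from 1500 nM to 20000 nM, because compound 1 itself stands at 5000 nM.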

Compound 3, half-maximal effective concentration: 5000 nM
Compound 3: the middle estimate sits on the measured number at the digits printed; low and high end bracket the measured number.
By their numbers in this assay, from the lowest: compounds 1, 2 and 3 (each within the scatter of the next).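

On the sulfonyl sulfur, replacing naphthalen-2-yl with a group holding one six-membered aromatic ring of carbon only, plus nitrogen and oxygen, gives no change at the digits printed from compound 1 to compound 3 (within the scatter) in this assay. Among the compounds shown here, this is the first step read at this position, and it shows that losing the second aromatic ring and adding hydrogen-bond donor and acceptor atoms together leave the read-out within the scatter for this pair. No measurement here bears on why the value holds.

Going by these compounds, it remains open whether any group on the sulfonyl sulfur can move the value beyond the scatter, for instance a carboxylic acid on the single ring or an n-butyl chain in place of the aromatic group. With no step beyond the scatter so far, the compounds shown do not yet identify any part of the structure that governs the value.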